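The source may report more compounds than this note shows. Statements on the series, on what has been measured and on what is new or still open speak of the compounds shown alone.

Working notes on the isoquinoline-type series in a functional assay on T47D cells (Homo sapiens) for cytotoxicity, read by CCK-8 assay and cell counting, with a stated time of 72 h; on this read-out higher numbers stand for weaker inhibition and lower numbers for stronger inhibition.

Compound 1 `COc1ccc(-c2cc3ccccc3c(-c3cccc(OC)c3)n2)cc1` gives 860 nM in this assay. Compound 2 `COc1ccc(-c2cc3ccccc3c(-c3cccc(N)c3)n2)cc1` differs from it by amino in place of methoxy on an aromatic carbon; compound 2 gives 950 nM, so the step of a 1.1-fold higher number from compound 1 to compound 2 (0.04 log units; within the scatter) lies within the scatter and supports no reading of a trend in either direction.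

Compound 3 `COc1cccc(-c2nc(-c3ccc(OC)c(OC)c3)cc3cc(C)ccc23)c1` carries a different core; the difference between the core of compound 3 and the core of compound 1 is not broken down here. In this assay compound 3 gives 7860 nM, the highest number of the three measured; its gap to compound 2, the nearer of the other two, and its gap to compound 1 both lie beyond the scatter.

Compound 4 `COc1ccc(-c2cc3cc(C)ccc3c(-c3cccc(N)c3)n2)cc1OC` has not yet been measured. It differs from compound 3 by amino in place of methoxy on an aromatic carbon, which is the same change as that from compound 1 to compound 2, made at the same place on the same kind of ring. For the measured compounds named here, since the one measured instance of this change, a 1.1-fold higher number from compound 1 to compound 2 (0.04 log units; within the scatter), stayed within the scatter, the step from compound 3 to compound 4 is expected to be about as small, roughly a 1.0-fold higher number from compound 3 to compound 4 (0.02 log units; within the scatter). On that basis compound 4 is estimated at 8200 nM in this assay, with a likely range from 3500 nM to 19000 nM. The estimate rests on a single prior instance of the change, so the range is kept wide.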

Compound 4, half-maximal inhibitory concentration: 450 nM
The estimate for compound 4 lay 18-fold (1.26 log units) above the measured number; the whole stated range lies above it.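

In this assay, amino in place of methoxy, read as 3-methoxyphenyl to 3-aminophenyl, gives a 17-fold lower number from compound 3 to compound 4 (1.24 log units; beyond the scatter), so on the core of compound 3 this single change carries a large effect. For the compounds shown here, the step does not transfer at a constant size from one core to the other: the same change on two cores in this assay, a 1.1-fold higher number (0.04 log units; within the scatter) from compound 1 to compound 2 and a 17-fold lower number (1.24 log units; beyond the scatter) from compound 3 to compound 4, 19-fold (1.29 log units) apart, beyond the scatter of two such steps What the two steps do not show is which feature of the core sets the size of the step, or whether either step is typical, since the series offers only two instances of the change and the two cores differ in more than one place.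

The compounds shown leave open whether the added methyl or the added methoxy that sets the core of compound 3 apart from the core of compound 1 governs the size of the step, a question that a pair carrying only one of the two groups would address. Also open, going by these compounds, is how a hydroxyl, a dimethylamino group or an acetamide in the place of the amino would read on either core.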